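Ethoxy in place of bromo on the aromatic carbon

This account rests on a few compounds, and the source may have more. Where it says the series, first, only, none or still open, it means among the compounds named here.

Measured in a functional assay on the whole organism (strain Albino Wistar) for inhibition, with Rattus norvegicus as the target, read by paw edema, with stated times of 1 h and 3 h, at a dose of 10 mg/kg by the oral route; on this read-out higher numbers stand for more inhibition at the one dose given (going by the name of the read-out) and lower numbers for less inhibition:
compound 1 `Clc1ccc(-n2cc(CSc3nc4ccccc4s3)nn2)cc1` gives 50%
compound 2 `Fc1ccc(-n2cc(CSc3nc4ccccc4s3)nn2)cc1` gives 77.8%
compound 3 `Brc1ccc(-n2cc(CSc3nc4ccccc4s3)nn2)cc1` gives 75%

Compound 3 and compound 2 lie within the scatter of each other, the gap being a number 2.8 percentage points lower from compound 2 to compound 3 (within the scatter), so neither is set above the other. Compound 3 does stand clearly above compound 1, by a number 25 percentage points higher from compound 1 to compound 3 (beyond the scatter), and compound 2 likewise by a number 27.8 percentage points higher from compound 1 to compound 2 (beyond the scatter). The three measured compounds share one core and differ only in the group on the aromatic carbon.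

Compound 4 `CCOc1ccc(-n2cc(CSc3nc4ccccc4s3)nn2)cc1` is not yet measured in this assay. It differs from compound 3 by ethoxy in place of bromo on an aromatic carbon. For the measured compounds named here, all three measured steps exchange one halogen for another at this carbon; none replaces a halogen with ethoxy, so no measured step bears directly on the change to compound 4. What the halogen steps do show is that the read-out at this position can move by a modest amount, as with a number 25 percentage points higher from compound 1 to compound 3 (beyond the scatter), or stay within the scatter, as with a number 2.8 percentage points lower from compound 2 to compound 3 (within the scatter). Going by the values given here, with no direct precedent, a wide range is expected for compound 4, centred somewhat below compound 3. Compound 4 is estimated at 62% (range 42% to 80%), which is expected to amount to a step of a number 13 percentage points lower from compound 3 to compound 4 (beyond the scatter).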

Compound 4, a percentage reported as inhibition, in the whole organism at one dose (the size of the read-out at that dose, not a potency): 38.3%
Compound 4: the middle estimate sits 23.7 percentage points above what was measured, and the stated range ends above it.
By their numbers in this assay, from the lowest: compound 4; then compound 1; then compounds 3 and 2 (each within the scatter of the next).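

On the aromatic carbon para to a large group, ethoxy is the first group shown that is not a halogen, and in this assay it gives the lowest number of the four compounds, with a number 36.7 percentage points lower from compound 3 to compound 4 (beyond the scatter) and a number 39.5 percentage points lower from compound 2 to compound 4 (beyond the scatter) as large steps and a number 11.7 percentage points lower from compound 1 to compound 4 (beyond the scatter) as a modest one. The halogen exchanges had shown this position moving by no more than a number 27.8 percentage points higher from compound 1 to compound 2 (beyond the scatter), so the change to ethoxy reveals a wider span at this carbon than those exchanges suggested, and compound 4 falls beyond the scatter even from compound 1, the lowest of the halogen compounds. The change replaces one heavy atom with no hydrogen-bond acceptor by three heavy atoms with one hydrogen-bond acceptor, so size and acceptor count shift together in this single step and cannot be read apart.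

Going by these compounds, whether the fall goes with the oxygen or with the chain remains open, and a methoxy group, a propyl chain or an amine on this carbon would help separate the two. The data at hand offer no measurement that accounts for the fall.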